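This account rests on a few compounds, and the source may have more. Where it says the series, first, only, none or still open, it means among the compounds named here.

Measured in an ADME assay on HMEC cells (Homo sapiens) for cytotoxicity, read by MTT assay; on this read-out higher numbers stand for weaker inhibition and lower numbers for stronger inhibition:
- compound 1 `Nc1ccccc1NC(=O)c1ccc(CNc2nc3ccc(Br)cc3s2)cc1`: 6000 nM
- compound 2 `Nc1ccccc1NC(=O)c1ccc(CSc2nc3ccc(NCc4ccccn4)cc3s2)cc1`: 8000 nM
- compound 3 `COc1ccc2nc(SCc3ccc(C(=O)Nc4ccccc4N)cc3)[nH]c2c1`: 10000 nM

Compound 2, at 8000 nM, cannot be told apart from the other two, since all three numbers lie within the usual scatter of one another. Compound 4 `Nc1ccccc1NC(=O)c1ccc(CSc2nc3ccccc3s2)cc1` has not yet been measured. It differs from compound 2 by a single change hydrogen in place of ((pyridin-2-yl)methyl)amino on an aromatic carbon. Among the measured compounds shown here, no measured pair shows what this change alone does in this assay. Compound 1 at 6000 nM and compound 3 at 10000 nM both lie within the scatter of compound 2, despite their different structures. The expected step of no change at the digits printed from compound 2 to compound 4 (within the scatter) therefore stays within the scatter, with no direction foreseen. For compound 4 the estimate is 8000 nM, with an expected range from 3000 nM to 20000 nM.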

Compound 4, half-maximal inhibitory concentration: 3000 nM
For compound 4 the middle estimate is 2.7-fold (0.43 log units) above the measured one; measured number inside the range.
By their numbers in this assay, from the lowest: compounds 4, 1, 2 and 3 (each within the scatter of the next, the first and the last beyond it).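

In this assay the swap of ((pyridin-2-yl)methyl)amino for hydrogen on this aromatic carbon gives a 2.7-fold lower number from compound 2 to compound 4 (0.43 log units; beyond the scatter) and this modest step lies beyond the scatter. The earlier compounds shown here differed from one another in more than one place, so none of them could show what this position does alone. Here the position proves sensitive to the change, with the bare hydrogen going with stronger inhibition than the larger group. Whether a small group at this carbon, such as a fluorine atom or a primary amine, would behave like hydrogen or like the larger group stays open, and nothing shown gives a reason for the step.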